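A few compounds are considered here, and "the series" means these few. Any claim that something is new, unique, unknown or untested is made for them only; others in the source may bear on it.

In a functional assay on CH1 cells (Homo sapiens) for inhibition, read by MTT assay, with a stated time of 96 h (a higher number here means a weaker inhibitor, a lower number a stronger inhibitor), compound 1 `CC(=O)O[C@H](CN)CC(=O)O/N=C1C(=C2/C(=O)Nc3ccccc32)/Nc2ccc(O)cc2/1` gives 1800 nM and compound 2 `NCCO/N=C1C(=C2/C(=O)Nc3ccccc32)/Nc2ccc(O)cc2/1` gives 1300 nM on the same read-out. For the measured compounds named here, these are the only two numbers available, and compound 2 stands level with compound 1, since the measured step between them is a 1.4-fold lower number from compound 1 to compound 2 (0.14 log units; within the scatter) and involves a change on an oxygen. Compound 3 `NCCO/N=C1C(=C2/C(=O)Nc3ccc(Br)cc32)/Nc2ccc(O)cc2/1` departs from compound 2 in a single place, namely bromo in place of hydrogen on an aromatic carbon on the shared core, with bromo in place of hydrogen on an aromatic carbon. Going by the values given here, no measured compound carries a bromo, so the data offer no direct precedent for this change. Among the compounds with values here, the one measured step, a 1.4-fold lower number from compound 1 to compound 2 (0.14 log units; within the scatter), replaced a much larger group and stayed within the scatter, but it lies at a different place and bears only loosely on this one. The estimate therefore stays close to compound 2, and the step expected in this assay is a 1.6-fold lower number from compound 2 to compound 3 (0.21 log units; within the scatter), with nothing beyond the scatter anticipated. For compound 3 the estimated value is 800 nM, with a range of 250 nM to 2200 nM expected.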

Compound 3, half-maximal inhibitory concentration: 280 nM
Beside the measured number, compound 3's estimate is 2.9-fold (0.46 log units) above it, and the stated range covers the measured number.
By their numbers in this assay, from the lowest: compound 3; then compounds 2 and 1 (each within the scatter of the next).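

In this assay, bromo in place of hydrogen on an aromatic carbon of the shared core gives a 4.6-fold lower number from compound 2 to compound 3 (0.67 log units; beyond the scatter) and is the only step among these compounds that lies beyond the scatter. For the compounds shown here, the other step, a 1.4-fold lower number from compound 1 to compound 2 (0.14 log units; within the scatter), swapped a much larger group on an oxygen, whereas compounds 1 and 2 both carry hydrogen on this aromatic carbon, so the new result is the first sign that this position, meta to a fused ring and para to a fused ring, can shift the number, here with a single heavy atom. No available evidence explains the size of this step, which rests on one pair of compounds.

Whether a chloro, a methyl or a methoxy group on this same carbon would give a step of similar size remains open, so the compounds shown cannot separate the effect of bromo itself from that of replacing the hydrogen with any other group. Going by these compounds, it is also open whether the bromo step would hold with a longer chain or a carboxylic acid on the oxygen in place of the aminoethyl chain of compound 3.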